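Working notes: from compound 2 to compound 3

The source may report more compounds than this note shows. Statements on the series, on what has been measured and on what is new or still open speak of the compounds shown alone.

Values in a functional assay on HCT-116 cells (Homo sapiens) for inhibition (a higher number here means a weaker inhibitor, a lower number a stronger inhibitor), so far:
- Compound 1 `COc1cc2oc(=O)cc(COC(=O)/C=C/c3ccc(Cl)cc3)c2cc1OC` gives > 10 ug/mL as a limit
- Compound 2 `COc1ccc(/C=C/C(=O)OCc2cc(=O)oc3cc(OC)c(OC)cc23)cc1O` gives 3.41 ug/mL

Within the data shown here, compound 2 at 3.41 ug/mL holds the only true number so far. The next structure is compound 3 `COc1cc2oc(=O)cc(COC(=O)/C=C/c3ccc(N)cc3)c2cc1OC` and the change is 4-aminophenyl in place of 3-hydroxy-4-methoxyphenyl on a double-bonded chain carbon bound to a double-bonded chain carbon with 4-aminophenyl in place of 3-hydroxy-4-methoxyphenyl. Among the measured compounds shown here, one measured step bears on this place: an at least 2.9-fold lower number from compound 1 to compound 2 (0.46 log units; beyond the scatter) is at least modest and came with the arrival of 3-hydroxy-4-methoxyphenyl. That group now leaves, so part of the gain is expected to be lost: the estimated step is a 2.2-fold higher number from compound 2 to compound 3 (0.34 log units; beyond the scatter) towards a higher number in this assay and no more than modest. For compound 3 the estimated value is 7.5 ug/mL with 2.5 ug/mL to 20 ug/mL as its range.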

Compound 3, half-maximal inhibitory concentration: > 10 ug/mL
Compound 3 gave a limit, no number; the forecaster's own chance of this, stated with the estimate: 35%; middle value at least 1.3-fold (0.12 log units) away from the limit.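

In this assay, 4-aminophenyl in place of 3-hydroxy-4-methoxyphenyl gives an at least 2.9-fold higher number from compound 2 to compound 3 (0.46 log units; beyond the scatter). Both groups count one hydrogen-bond donor, and that count alone does not keep the number of compound 2. Compound 3 ends at a limit, as does compound 1, and the step between those two cannot be read: the limit of > 10 ug/mL in this assay, at which 2 of the 3 values shown sit.

Left open is which part of 3-hydroxy-4-methoxyphenyl goes with the lower number. A 3-hydroxyphenyl or a 4-methoxyphenyl group at this place would separate the two parts.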